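The source may report more compounds than this note shows. Statements on the series, on what has been measured and on what is new or still open speak of the compounds shown alone.

Measured compounds and their values:

- Compound 1, `COC(=O)c1cc(-c2cccc(NC(=O)c3ccc(/C=C/C(=O)c4cccs4)cc3)c2)on1`: "not determined" (no result reported)
- Compound 2, `CC(C)Cc1ccc(C(=O)/C=C/c2ccc(C(=O)O)cc2)cc1`: < 10 ug/mL
- Compound 3, `COC(=O)c1cc(-c2cccc(NC(=O)c3ccc(/C=C/C(=O)c4cccc(C(F)(F)F)c4)cc3)c2)on1`: > 20 ug/mL

Three compounds have been examined in an ADME assay on Vero cells (Chlorocebus sabaeus) for cytotoxicity, read by MTT assay, with a stated time of 72 h; on this read-out lower numbers stand for higher toxicity in this test and higher numbers for lower toxicity in this test. For compound 1 no result is reported, "not determined" (no result reported). For compound 2 only a limit is reported, < 10 ug/mL, which marks an edge of the test rather than a number; this is the limit of < 10 ug/mL in this assay, at which 1 of the 3 values shown sits. For compound 3 the outcome is likewise a limit, > 20 ug/mL, the edge described by the limit of > 20 ug/mL in this assay, at which 1 of the 3 values shown sits. Among the compounds with values here, compound 3 is therefore placed at the low-toxicity edge of this assay, and no single number for it exists; the other two entries give no number either, so no step between measured compounds can be counted here.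

The next compound, compound 4, `COC(=O)c1cc(-c2cccc(NC(=O)c3ccc(/C=C/C(=O)c4ccccc4Cl)cc3)c2)on1`, shares the core of compound 3 and differs from it at one point, on the carbonyl carbon whose other neighbour is a double-bonded chain carbon: 2-chlorophenyl in place of 3-(trifluoromethyl)phenyl on a carbonyl carbon. Both groups are a single six-membered aromatic ring of carbon only, without donors or acceptors and without charge.

Within the data shown here, with no measured step to lean on, the step from compound 3 to compound 4 is expected to stay within the scatter, and the estimate of a step that the limit leaves unreadable from compound 3 to compound 4 means no change beyond it. For compound 4 a value of 25 ug/mL in this assay is expected, with a range from 10 ug/mL to 60 ug/mL, and quite possibly again only a limit.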

Compound 4, half-maximal cytotoxic concentration: > 25 ug/mL
Compound 4 gave a limit, no number; the forecaster's own chance of this, stated with the estimate: 65%; the middle value lies on the limit itself.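

In this assay compound 3 gives > 20 ug/mL, a limit and not a number. Within the data shown here, compound 4 gives > 25 ug/mL, again a limit, so no step between compound 3 and compound 4 can be read. The compounds shown leave open how far 2-chlorophenyl in place of 3-(trifluoromethyl)phenyl on a carbonyl carbon shifts the half-maximal cytotoxic concentration, if at all.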